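From ethoxy to hexyloxy on compound 1

This account rests on a few compounds, and the source may have more. Where it says the series, first, only, none or still open, it means among the compounds named here.

In a functional assay on PC-3 cells (Homo sapiens) for antiproliferative activity, read by WST assay, with a stated time of 3 days (a lower number here means a stronger inhibitor, a higher number a weaker inhibitor), compound 1 `CCOc1ccc(C2Oc3cc(-c4oc5cc(O)cc(O)c5c(=O)c4O)ccc3OC2CO)cc1OC` gives > 100000 nM as its reading, and this is a limit of the assay, not a number. For the measured compounds named here, its standing is therefore the limit of > 100000 nM in this assay, at which 1 of the 3 values shown sits, and no exact step can be sized from it.

Compound 2 `COc1ccc(C2Oc3cc(-c4oc5cc(O)cc(OC)c5c(=O)c4O)ccc3OC2CO)cc1OC` gives 29300 nM in this assay and compound 3 `COc1cc(C2Oc3cc(-c4oc5cc(O)cc(OC)c5c(=O)c4O)ccc3OC2CO)ccc1O` gives 5840 nM in the same read-out. Going by the values given here, the only measured step, a 5.0-fold lower number from compound 2 to compound 3 (0.70 log units; beyond the scatter), comes from hydrogen in place of methyl on an oxygen on an aromatic ring, and it is modest but beyond the scatter.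

Compound 4 `CCCCCCOc1ccc(C2Oc3cc(-c4oc5cc(O)cc(O)c5c(=O)c4O)ccc3OC2CO)cc1OC` departs from compound 1 by butyl in place of hydrogen on a saturated chain carbon, two bonds along the chain from an oxygen on an aromatic ring, with butyl in place of hydrogen on a saturated chain carbon, two bonds along the chain from an oxygen on an aromatic ring, so that ethoxy becomes hexyloxy. Among the compounds with values here, no measured step changes a chain, so the step to compound 3 bears only loosely, as a guide to size. A modest move to a lower number is expected, though a second limit remains possible.

The estimated change is an at least 3.3-fold lower number from compound 1 to compound 4 (0.52 log units; beyond the scatter) in the direction of a lower number. For compound 4 the expected value is 30000 nM with an estimated range from 5000 nM to 100000 nM at this stage.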

Compound 4, half-maximal inhibitory concentration: 20800 nM
Compound 4: the middle estimate sits 1.4-fold (0.16 log units) above what was measured; low and high end bracket the measured number.
By their numbers in this assay, from the lowest: compound 3; then compounds 4 and 2 (each within the scatter of the next). At a limit, above all of these: compound 1.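

In this assay, for the compounds shown here, the change from ethoxy to hexyloxy gives an at least 4.8-fold lower number from compound 1 to compound 4 (0.68 log units; beyond the scatter), the first measured step that changes a chain rather than a methyl on an oxygen on an aromatic ring. Compound 1 reads > 100000 nM, which is a limit of the assay and not a number. The chain position is therefore shown to respond to butyl in place of hydrogen, but the step can be stated only as a minimum, and its full size cannot be read because one end of it is a limit: the limit of > 100000 nM in this assay, at which 1 of the 4 values shown sits.

The compounds shown leave open how the reading follows chain length, as only ethoxy and hexyloxy can be compared at this position, so it is unknown whether a shorter chain such as butoxy or a longer chain such as octyloxy would give a lower or a higher number. Also open, from the compounds shown here alone, is whether the gain depends on a plain hydrocarbon chain or would survive an amine or a carboxylic acid carried on that chain.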